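This account rests on a few compounds, and the source may have more. Where it says the series, first, only, none or still open, it means among the compounds named here.

In a functional assay on QG-56 cells (Homo sapiens) for antiproliferative activity (a lower number here means a stronger inhibitor, a higher number a weaker inhibitor), compound 1 `COc1cccc(-c2cc([N+](=O)[O-])cc3cc(C(O)(c4ccc(C#N)cc4)c4cncn4C)oc23)c1` gives 38.8 nM and compound 2 `COc1cccc(-c2cc(C=O)cc3cc(C(O)(c4ccc(C#N)cc4)c4cncn4C)oc23)c1` gives 15.2 nM. Compound 2 therefore holds the lower of the two numbers, and the gap between them lies beyond the scatter. Compound 3 `COC(=O)c1cc(-c2cccc(OC)c2)c2oc(C(O)(c3ccc(C#N)cc3)c3cncn3C)cc2c1` is still unmeasured and differs from compound 2 in one place: methoxy in place of hydrogen on a carbonyl carbon. This is methoxy in place of hydrogen on a carbonyl carbon, which turns formyl into methoxycarbonyl.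

Among the measured compounds shown here, only one measured step bears on this substituent: a 2.6-fold lower number from compound 1 to compound 2 (0.41 log units; beyond the scatter), a modest change with formyl in place of nitro on an aromatic carbon. For the measured compounds named here, that single step shows that a swap here can move the number, but it does not fix a direction for methoxycarbonyl, which no measured compound carries. Going by the values given here, a step of similar modest size is expected, leaning towards a higher number, as compound 2 at 15.2 nM is the lowest value so far. The expected change is estimated as a 1.7-fold higher number from compound 2 to compound 3 (0.23 log units; within the scatter). For compound 3 the estimated value is 26 nM, with an expected range of 10 nM to 65 nM.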

Compound 3, half-maximal inhibitory concentration: 36.3 nM
Compound 3: middle estimate off by 1.4-fold (0.14 log units), on the low side, within the range that was stated.
By their numbers in this assay, from the lowest: compound 2; then compounds 3 and 1 (each within the scatter of the next).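

In this assay the change from formyl to methoxycarbonyl gives a 2.4-fold higher number from compound 2 to compound 3 (0.38 log units; beyond the scatter) and so supplies a second measured step at this aromatic position, with a direction for a group that had none before; compound 2 with formyl now stands apart from both other compounds by steps beyond the scatter. The comparison of nitro with methoxycarbonyl gives a 1.1-fold lower number from compound 1 to compound 3 (0.03 log units; within the scatter) and so does not separate these two groups, which leaves formyl as the only one of the three substituents with a distinct number. Nothing at hand accounts for why formyl stands apart from the other two groups.

The compounds shown leave open how a carboxylic acid, a primary amide, a hydroxymethyl group or an amine on this aromatic carbon would compare with formyl. All three compounds carry the same shared core, so whether this order of substituents holds on any other core remains unsettled.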